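A few compounds are considered here, and "the series" means these few. Any claim that something is new, unique, unknown or untested is made for them only; others in the source may bear on it.

Measured compounds:
- compound 1, `CC#C[C@@H](Cc1nnn[nH]1)c1ccc(OCc2ccc3scc(-c4cc(OCCOC)ccc4C)c3c2)cc1`: 85 nM
- compound 2, `CC#C[C@@H](Cc1nnn[nH]1)c1ccc(OCc2ccc3scc(C4CCCCC4)c3c2)cc1`: 107 nM
- compound 3, `CC#C[C@@H](Cc1nnn[nH]1)c1ccc(OCc2ccc3sc(C#N)c(-c4ccccc4C)c3c2)cc1`: 16 nM

In a functional assay on cells for agonist activity at Free fatty acid receptor 1 (Homo sapiens), read by FLIPR and calcium flux (a higher number here means that more compound is needed for the effect, a lower number that less compound is needed), compound 3 gives the lowest number of the three and is the most potent compound measured, ahead of compound 1 by a clear margin and of compound 2 by a somewhat larger one. For the measured compounds named here, the only one-place step among the measured compounds, a 1.3-fold higher number from compound 1 to compound 2 (0.10 log units; within the scatter), concerns a different part of the shared core and offers no guide to a change at the ring carbon in question.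

Compound 4, `CC#C[C@@H](Cc1nnn[nH]1)c1ccc(OCc2ccc3sc(I)c(-c4ccccc4C)c3c2)cc1`, differs from compound 3 by iodo in place of cyano on an aromatic carbon. Going by the values given here, no measured step bears on this exchange, so the expectation for compound 4 rests on compound 3 alone, with wide uncertainty. Compound 4 is expected to stay close to compound 3, with a slightly higher number in this assay as the likelier outcome, a step of a 1.9-fold higher number from compound 3 to compound 4 (0.27 log units; within the scatter). The estimate for compound 4 is 30 nM, with a range from 8 nM to 110 nM.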

Compound 4, half-maximal effective concentration: 28 nM
For compound 4 the middle estimate is 1.1-fold (0.03 log units) above the measured one, and the stated range covers the measured number.
By their numbers in this assay, from the lowest: compounds 3 and 4 (each within the scatter of the next); then compounds 1 and 2 (each within the scatter of the next).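

At the carbon next to the ring sulfur, next to the ring atom that bears a 2-methylphenyl group, this assay shows a 1.8-fold higher number from compound 3 to compound 4 (0.24 log units; within the scatter) for iodo in place of cyano. In this one pair, a cyano with its triple bond and one hydrogen-bond acceptor can give way to a single iodine atom, counted with no hydrogen-bond acceptor, and the two numbers remain within the scatter of each other. Nothing available explains why this exchange is tolerated.

What remains open is how far this tolerance reaches, since cyano and iodo are the only two groups shown at this carbon. A methyl, an amine or a carboxylic acid there could keep the number in the same range or move it well away, and the compounds shown give no guide to which.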